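From Compound 2 to Compound 3: Expected Cytotoxicity

The source may report more compounds than this note shows. Statements on the series, on what has been measured and on what is new or still open speak of the compounds shown alone.

Compound 1 `CCc1ccc(-n2cc(COC(=O)c3c(C)nc4ccccc4c3-c3ccccc3)nn2)cc1` belongs to this series, but in an ADME assay on J774.A1 cells (Mus musculus) for cytotoxicity, read by MTT assay, with a stated time of 48 h (on this read-out lower numbers stand for higher toxicity in this test and higher numbers for lower toxicity in this test), compound 1 gives "not determined" (no result reported). Compound 2 `CCc1ccc(-n2cc(COC(=O)c3c(C)nc4ccc(Cl)cc4c3-c3ccccc3)nn2)cc1` therefore stands alone among the numbers shown: in this assay compound 2 gives 99000 nM, and with no second number there is nothing to rank it against. Compound 3 `Cc1nc2ccc(Cl)cc2c(-c2ccccc2)c1C(=O)OCc1cn(Cc2ccccc2)nn1` has not yet been measured. It differs from compound 2 in one place, (benzyl in place of 4-ethylphenyl on an aromatic nitrogen), so the group on the aromatic nitrogen of the five-membered aromatic ring with 3 nitrogen changes while the rest of the shared core stays the same. Within the data shown here, no pair of measured compounds shows what such a change does in this assay, so the account rests on compound 2 alone. The step from compound 2 to compound 3 is expected to stay within the scatter, with no clear direction: a 1.0-fold higher number from compound 2 to compound 3 (0.00 log units; within the scatter). In this assay compound 3 is estimated at 100000 nM, with a range from 40000 nM to 250000 nM.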

Compound 3, half-maximal cytotoxic concentration: 35000 nM
Compound 3: the middle estimate sits 2.9-fold (0.46 log units) above what was measured, outside the stated range (below it).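

In this assay, among these compounds, benzyl in place of 4-ethylphenyl on the aromatic nitrogen gives a 2.8-fold lower number from compound 2 to compound 3 (0.45 log units; beyond the scatter), the first readable step, so the group at this position does register in the read-out, though only modestly. The change is a small one by what can be counted: both groups hold one six-membered aromatic ring of carbon only, neither has hydrogen-bond donors or acceptors or a net charge, and benzyl is the smaller by heavy-atom count, yet this single pair already moves the number beyond the usual scatter. No measurement shown here accounts for the difference between the two groups, so the step stands as an observation only.

On these data alone, with one pair, it remains open whether the step follows from the ring's distance to the aromatic nitrogen, from the loss of the ethyl group, or from both together, and whether it would recur on a shared core without the chlorine. As far as these compounds go, how this assay would respond to a longer chain such as phenylethyl at this position, or to an amine or a carboxylic acid on the benzyl ring, also remains open.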